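A few compounds are considered here, and "the series" means these few. Any claim that something is new, unique, unknown or untested is made for them only; others in the source may bear on it.

Compound 1 `CCc1ccc(NS(=O)(=O)c2ccc(N3CCNC3=O)cc2)cc1` is the starting point. In a functional assay on HT-29 cells (Homo sapiens) for antiproliferative activity, read by sulforhodamine B assay, with a stated time of 48 h (a higher number here means a weaker inhibitor, a lower number a stronger inhibitor), compound 1 gives 660 nM, the only plain number among the two measurements shown. Compound 2 `CCCCCCCc1ccc(NS(=O)(=O)c2ccc(N3CCNC3=O)cc2)cc1` reaches only a limit of this assay, > 1000 nM. That gives an at least 1.5-fold higher number from compound 1 to compound 2 (0.18 log units; that floor lies within the scatter). Compound 3 `Cc1ccc(NS(=O)(=O)c2ccc(N3CCNC3=O)cc2)c(C)c1` differs from compound 1 by 2,4-dimethylphenyl in place of 4-ethylphenyl on a sulfonamide nitrogen. Among the compounds with values here, no measured step covers this rearrangement of the same atoms, and the single step from compound 1 to compound 2 concerns a different change, so little more than a small shift is expected, if any, in this assay. Compound 3 is therefore estimated at 900 nM, between 350 nM and 2500 nM, an expected step of a 1.4-fold higher number from compound 1 to compound 3 (0.13 log units; within the scatter).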

Compound 3, half-maximal inhibitory concentration: 180 nM
The estimate for compound 3 lay 5.0-fold (0.70 log units) above the measured number, outside the stated range (below it).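

The aryl group on the sulfonamide nitrogen is sensitive to how its carbons are arranged, not only to which atoms it holds: in this assay, 2,4-dimethylphenyl in place of 4-ethylphenyl gives a 3.7-fold lower number from compound 1 to compound 3 (0.56 log units; beyond the scatter). Compound 1 and compound 3 have the same atoms, so this arrangement alone separates them. Nothing measured here gives a reason for this step. On these data alone, whether both methyl groups of 2,4-dimethylphenyl are needed remains open, as does how a chlorophenyl, a methoxyphenyl or a pyridine ring would compare on the same nitrogen.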